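A Methoxy Step Repeated on a Second Core

This account rests on a few compounds, and the source may have more. Where it says the series, first, only, none or still open, it means among the compounds named here.

Three compounds were measured in a functional assay on NCI-H460 cells (Homo sapiens) for cytotoxicity, read by sulforhodamine B assay, with a stated time of 48 h, tested at 100 uM; a higher number here means a weaker effect of the compound at the concentration tested, a lower number a stronger effect. Compound 3 `COc1ccc(-c2cc(/C=C/C(=O)c3ccc(N)cc3)[nH]n2)cc1OC` gives -76%, compound 1 `COc1cc(-c2cc(/C=C/C(=O)c3ccc(N)cc3)[nH]n2)cc(OC)c1OC` gives -59%, and compound 2 `COc1ccc(C(=O)/C=C/c2cc(-c3cc(OC)c(OC)c(OC)c3)n[nH]2)cc1OC` gives -65%. The change from compound 3 to compound 1 is methoxy in place of hydrogen on an aromatic carbon, and it produced a step of a number 17 percentage points higher from compound 3 to compound 1 (beyond the scatter). The step from compound 1 to compound 2 was a number 6 percentage points lower from compound 1 to compound 2 (within the scatter), so compound 1 and compound 2 are not distinguished by their numbers. Compound 4 `COc1cc(C(=O)/C=C/c2cc(-c3cc(OC)c(OC)c(OC)c3)n[nH]2)cc(OC)c1OC` has not yet been measured. It differs from compound 2 by methoxy in place of hydrogen on an aromatic carbon, the same change as that from compound 3 to compound 1, with the surroundings of the place described in identical words. The difference between the core of compound 2 and the core of compound 3 is not broken down here. Because the earlier methoxy step gave a number 17 percentage points higher from compound 3 to compound 1 (beyond the scatter), compound 4 is expected to show a step of similar size, a number 17 percentage points higher from compound 2 to compound 4 (beyond the scatter). Compound 4 is therefore estimated at -48%, with a likely range from -66% to -30%.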

Compound 4, a percentage reported as activity, at one concentration (the size of the read-out at that concentration, not a potency): -55%
Estimate against measurement, compound 4: 7 percentage points above; low and high end bracket the measured number.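

In this assay the methoxy change gave a step of a number 10 percentage points higher from compound 2 to compound 4 (within the scatter), so these two compounds are not told apart by their numbers. Set beside the earlier case, the two steps point the same way and do not differ in size beyond what repeated measurement allows: the same change on two cores in this assay, a number 17 percentage points higher (beyond the scatter) from compound 3 to compound 1 and a number 10 percentage points higher (within the scatter) from compound 2 to compound 4, 7 percentage points apart, within the scatter of two such steps. For the compounds shown here, this fits the change carrying over from one core to the other, but it rests on only two pairs, one of them within the scatter on its own, so it shows neither a fixed step size nor that the step would hold on a third core.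

The compounds shown leave open whether another group in the same place, such as ethoxy, a hydroxyl or a fluorine atom, would give a step like that of methoxy. Each compound was also read at a single concentration, so the numbers speak only of a stronger or weaker effect at that concentration.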